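The source may report more compounds than this note shows. Statements on the series, on what has been measured and on what is new or still open speak of the compounds shown alone.

Measured in a functional assay on CCRF-CEM cells (Homo sapiens) for antiproliferative activity, with a stated time of 72 h; on this read-out higher numbers stand for weaker inhibition and lower numbers for stronger inhibition:
- Compound 1 `OC[C@H]1O[C@@H](n2cnc3c(NCc4ccccc4Br)ncnc32)[C@H](O)[C@@H]1O` gives 12300 nM
- Compound 2 `COc1ccc(CNc2ncnc3c2ncn3[C@@H]2O[C@H](CO)[C@@H](O)[C@H]2O)c(OC)c1` gives > 166000 nM (a limit of the assay, not a number)
- Compound 3 `OC[C@H]1O[C@@H](n2cnc3c(NCc4ccc(F)c(F)c4F)ncnc32)[C@H](O)[C@@H]1O` gives 58200 nM

Of the two exact numbers, compound 3 holds the higher one. Compound 4 `OC[C@H]1O[C@@H](n2cnc3c(NCc4ccc(F)c(Cl)c4)ncnc32)[C@H](O)[C@@H]1O` carries 3-chloro-4-fluorophenyl in place of 2,3,4-trifluorophenyl on a saturated chain carbon bound to a nitrogen on an aromatic ring.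

Two measured changes at this same place bear on it: a 4.7-fold higher number from compound 1 to compound 3 (0.68 log units; beyond the scatter), a modest step, and an at least 2.8-fold lower number from compound 2 to compound 3 (0.45 log units; beyond the scatter), at least modest. Like compound 1 and compound 3, compound 4 has only halogen atoms on this ring, so it is expected to fall in their range. A modest drop in this assay is expected: a 2.3-fold lower number from compound 3 to compound 4 (0.37 log units; beyond the scatter). For compound 4 the estimated value is 25000 nM, with an expected range from 8000 nM to 90000 nM.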

Compound 4, half-maximal inhibitory concentration: 3400 nM
Compound 4: middle estimate off by 7.4-fold (0.87 log units), on the high side; the whole stated range lies above it.
By their numbers in this assay, from the lowest: compound 4; then compound 1; then compound 3. At a limit, above all of these: compound 2.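

In this assay, rings carrying only halogen atoms do not behave alike at this position: a 17-fold lower number from compound 3 to compound 4 (1.23 log units; beyond the scatter) is a large step within that set. With a 3.6-fold lower number from compound 1 to compound 4 (0.56 log units; beyond the scatter), a modest step, compound 4 is the strongest inhibitor of the four shown. The an at least 48-fold lower number from compound 2 to compound 4 (1.68 log units; beyond the scatter) rests on a limit of the assay, not a number: the limit of > 166000 nM in this assay, at which 1 of the 4 values shown sits.

From the compounds shown here alone, the number and placement of the halogens and the kind of halogen all differ between these rings, so their separate shares stay open. Going by these compounds, how a ring carrying a nitrile or a trifluoromethyl group would fare also remains open.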